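The source may report more compounds than this note shows. Statements on the series, on what has been measured and on what is new or still open speak of the compounds shown alone.

In an ADME assay on the whole organism (strain Swiss Webster) for pharmacokinetics, with Mus musculus as the target, using cassette dosing, at a dose of 0.3 mg/kg by the oral route (on this read-out lower numbers stand for lower exposure and higher numbers for higher exposure at the dose given), compound 2 (`CCC(C)C(=O)N1CCC(NC(=O)Nc2ccc(C(C)C)cc2)CC1`) gives 90 nM. In the same assay, compound 1 (`O=C(Nc1ccc(C(F)(F)F)cc1)NC1CCN(C(=O)C2CC2)CC1`) gives 960 nM. For the measured compounds named here, compound 2 has the lower of the two numbers so far, and the gap between them lies beyond the scatter. Compound 3 (`CCC(C)C(=O)N1CCC(NC(=O)Nc2ccc(C(F)(C(F)(F)F)C(F)(F)F)cc2)CC1`) carries 1,2,2,2-tetrafluoro-1-(trifluoromethyl)ethyl in place of isopropyl on an aromatic carbon. Going by the values given here, no measured pair isolates this change. Among the compounds with values here, the only weak guide is compound 1 at 960 nM, which also carries fluorine on its aromatic ring but differs from compound 2 in more than one place. A moderate rise in this assay is therefore expected, with the expected size being a 3.3-fold higher number from compound 2 to compound 3 (0.52 log units; beyond the scatter). For compound 3 the estimated value is 300 nM, with an expected range of 80 nM to 1100 nM.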

Compound 3, maximal plasma concentration: 135 nM
Compound 3: the middle estimate sits 2.2-fold (0.35 log units) above what was measured, within the range that was stated.
By their numbers in this assay, from the lowest: compounds 2 and 3 (each within the scatter of the next); then compound 1.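

For the compounds shown here, the exchange of isopropyl for 1,2,2,2-tetrafluoro-1-(trifluoromethyl)ethyl on this aromatic carbon gives in this assay a step of a 1.5-fold higher number from compound 2 to compound 3 (0.18 log units; within the scatter) and is the only single-place change available at this position. Here, a group of 10 heavy atoms in place of one of 3 leaves maximal plasma concentration within the scatter. Nothing at hand bears on why the read-out holds at this position.

Open, going by these compounds, is whether an amine or a carboxylic acid at this position would give a step beyond the scatter. Also open, on these data alone, is whether the same exchange on the core of compound 1 would give a comparable step.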